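This account rests on a few compounds, and the source may have more. Where it says the series, first, only, none or still open, it means among the compounds named here.

Compound 1 `COc1ccc(S(=O)(=O)c2cnc3cc(Cl)ccc3c2N2CCC(C)CC2)cc1Cl` in an assay on isolated protein for displacement of a labelled ligand from metabotropic glutamate receptor 5 (Homo sapiens), with a stated time of 60 min, tested at 1 uM (a lower number here means less inhibition, a higher number more inhibition at the concentration tested (going by the name of the read-out)), gives 93%.
Compound 2 `COc1ccc2ncc(S(=O)(=O)c3ccc(Cl)c(Cl)c3)c(N3CCC(C)CC3)c2c1` in this assay gives 87%.

Both numbers are high, and the gap between compound 1 and compound 2 lies within the usual scatter, so the two cannot be told apart on these figures. Compound 3 `COc1cccc(S(=O)(=O)c2cnc3cc(Cl)ccc3c2N2CCC(C)CC2)c1` differs from compound 1 in one place: 3-methoxyphenyl in place of 3-chloro-4-methoxyphenyl on a sulfonyl sulfur. Within the data shown here, no pair of measured compounds shows what a change on this ring does, so nothing here fixes the size of the step. The chlorine is simply gone, and a modest fall is expected, a number 15 percentage points lower from compound 1 to compound 3 (beyond the scatter). Compound 3 is therefore estimated at 78%, with a range from 55% to 95%.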

Compound 3, a percentage reported as inhibition, at one concentration (the size of the read-out at that concentration, not a potency): 93%
The estimate for compound 3 lay 15 percentage points below the measured number, and the stated range covers the measured number.
By their numbers in this assay, from the lowest: compounds 2, 1 and 3 (each within the scatter of the next).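

In this assay replacing 3-chloro-4-methoxyphenyl with 3-methoxyphenyl on the sulfonyl sulfur gives no change at the digits printed from compound 1 to compound 3 (within the scatter) and so the chlorine is not required for a high reading at this one concentration. The earlier pair could not show this, as compound 1 and compound 2 differ in more than one place. Nothing measured here gives a reason for the result.

Going by these compounds, whether this ring would keep the reading with an amine or a carboxylic acid in place of the methoxy group remains open. A single concentration also leaves any difference in potency between compound 1 and compound 3 unseen.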